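Swapping the Amide Arm for an Imidazole Ring

This account rests on a few compounds, and the source may have more. Where it says the series, first, only, none or still open, it means among the compounds named here.

Compound 2 `CCOc1ccc(-c2c(C#N)c(N)nc(SCC(N)=O)c2C#N)cc1` has the higher of the two numbers recorded in an assay on CHO cells for displacement of a labelled ligand from adenosine receptor A1 (Homo sapiens), read by scintillation counting, with a stated time of 90 min (on this read-out higher numbers stand for weaker inhibition and lower numbers for stronger inhibition), where compound 2 gives 345 nM. Compound 1 `C=CCOc1ccc(-c2c(C#N)c(N)nc(SCC(N)=O)c2C#N)cc1` gives 323 nM in this assay. Among the measured compounds shown here, the only measured step, a 1.1-fold higher number from compound 1 to compound 2 (0.03 log units; within the scatter), concerns the chain on the aromatic oxygen, not the sulfur side. Compound 3 `CCOc1ccc(-c2c(C#N)c(N)nc(SCc3ncc[nH]3)c2C#N)cc1` differs from compound 2 by 1H-imidazol-2-yl in place of carbamoyl on a saturated chain carbon bound to a sulfur. Nothing measured bears on a change at this place, so the expectation rests on compound 2 alone. The expected step for compound 3 is a 1.0-fold higher number from compound 2 to compound 3 (0.01 log units; within the scatter), with a wide range. The estimate for compound 3 is 350 nM, between 100 nM and 1200 nM.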

Compound 3, inhibition constant: 8.2 nM
Compound 3: the middle estimate sits 43-fold (1.63 log units) above what was measured, and the stated range ends above it.
By their numbers in this assay, from the lowest: compound 3; then compounds 1 and 2 (each within the scatter of the next).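

Among the compounds shown here, the group on the saturated chain carbon bound to a sulfur matters far more in this assay than the earlier compounds could show: 1H-imidazol-2-yl in place of carbamoyl gives a 42-fold lower number from compound 2 to compound 3 (1.62 log units; beyond the scatter) at this place. For the compounds shown here, the only earlier step concerned the chain on the aromatic oxygen and stayed within the scatter, so this is the first sign that the sulfur side can move the number strongly. Nothing measured here explains why this change has so large an effect.

As far as these compounds go, whether the stronger inhibition needs the imidazole ring itself stays open. A pyridine, a thiazole or a simple amine at this place would test that, as would a longer chain joining the sulfur to the ring.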